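The compounds below may be only part of what the source reports. "The series", "measured", "known", "first", "only" and "open" are said of these compounds alone.

Compound 1 `Cn1c(-c2cccs2)nnc1[S+](C)[O-]` and compound 2 `Cn1c(-c2cccs2)nnc1S(C)(=O)=O` share one core, while compound 3 `Cc1ccc(-c2nnc([S+](C)[O-])n2C)cc1` and the not yet measured compound 4 `Cc1ccc(-c2nnc(S(C)(=O)=O)n2C)cc1` share another; how the two cores differ is not broken down here. In a functional assay on the whole organism for antagonist activity, with Mus musculus as the target (on this read-out lower numbers stand for an effect already at smaller amounts and higher numbers for an effect only at larger amounts of compound), compound 1 gives only a limit of the assay, > 200 mg/kg. In this assay compound 2 likewise gives only a limit, > 200 mg/kg. In this assay compound 3 also gives only a limit, > 200 mg/kg. The change from compound 1 to compound 2, (a group of 4 heavy atoms (1 carbon, 2 oxygen, 1 sulfur; no ring) in place of a group of 3 heavy atoms (1 carbon, 1 oxygen, 1 sulfur; no ring), on an aromatic carbon), made a step that the two limits leave unreadable from compound 1 to compound 2. Compound 4 carries the same kind of change, (a group of 4 heavy atoms (1 carbon, 2 oxygen, 1 sulfur; no ring) in place of a group of 3 heavy atoms (1 carbon, 1 oxygen, 1 sulfur; no ring), on an aromatic carbon). Because (the limit of > 200 mg/kg in this assay, at which 3 of the 3 values shown sit), the step expected here is a step that the limit leaves unreadable from compound 3 to compound 4. Compound 4 is thus expected to give 300 mg/kg, estimated between 150 mg/kg and 1000 mg/kg.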

Compound 4, dose for half-maximal effect: > 200 mg/kg
Compound 4 ended at the assay's limit (the forecaster's own chance of this, stated with the estimate: 85%); the middle value lies beyond the limit too.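

No step can be read from compound 3 to compound 4, because both values are only limits: the limit of > 200 mg/kg in this assay, at which 4 of the 4 values shown sit.

As far as these compounds go, whether the methylsulfonyl group changes the dose needed in this assay stays open, as does the actual dose for any of the four compounds.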